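Moving a fluorine around the phenyl ring

A few compounds are considered here, and "the series" means these few. Any claim that something is new, unique, unknown or untested is made for them only; others in the source may bear on it.

Measured so far:
compound 1, `NC(N)=NC(=O)c1nc(Cl)c(NCc2ccccc2Cl)nc1N`: 31%
compound 2, `NC(N)=NC(=O)c1nc(Cl)c(NCc2ccc(Cl)cc2)nc1N`: 46%
compound 3, `NC(N)=NC(=O)c1nc(Cl)c(NCc2cccc(F)c2)nc1N`: 29%

All three were tested in an assay for inhibition of acid-sensing ion channel 3 (Homo sapiens), read by patch clamp, tested at 1 uM; on this read-out higher numbers stand for more inhibition at the one concentration tested (going by the name of the read-out) and lower numbers for less inhibition. Compound 3 has the lowest of the three numbers, but its gap to compound 1 is small: a number 2 percentage points lower from compound 1 to compound 3 (within the scatter). Only compound 2 stands clearly apart, as shown by a number 15 percentage points higher from compound 1 to compound 2 (beyond the scatter) and by a number 17 percentage points lower from compound 2 to compound 3 (beyond the scatter).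

Compound 4, `NC(N)=NC(=O)c1nc(Cl)c(NCc2ccccc2F)nc1N`, has not yet been measured. It differs from compound 3 in one place: 2-fluorophenyl in place of 3-fluorophenyl on a saturated chain carbon bound to a nitrogen on an aromatic ring.

Among the measured compounds shown here, two measured steps bear on this change. The step of a number 2 percentage points lower from compound 1 to compound 3 (within the scatter) compares a 2-chlorophenyl with the 3-fluorophenyl in the same place and lies within the scatter, so a halogen on the ring nearer the chain carbon gave no visible change against compound 3. The step of a number 17 percentage points lower from compound 2 to compound 3 (beyond the scatter) shows that only the 4-chlorophenyl of compound 2 stood apart. For the measured compounds named here, no measured pair contains a 2-fluorophenyl. Since compound 1 with its 2-chlorophenyl gives 31%, close to compound 3, compound 4 is expected to remain in the same region.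

Compound 4 is therefore estimated to give 30%, with a range from 18% to 42%. The expected step of a number 1 percentage points higher from compound 3 to compound 4 (within the scatter) is estimated to stay within the scatter.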

Compound 4, a percentage reported as inhibition, at one concentration (the size of the read-out at that concentration, not a potency): 26%
Compound 4: middle estimate off by 4 percentage points, on the high side; measured number inside the range.
By their numbers in this assay, from the lowest: compounds 4, 3 and 1 (each within the scatter of the next); then compound 2.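

In this assay, the fluorine's two ring placements are not told apart: with a number 3 percentage points lower from compound 3 to compound 4 (within the scatter) as the step, 2-fluorophenyl and 3-fluorophenyl read alike on a saturated chain carbon bound to a nitrogen on an aromatic ring. Compounds 1 and 4 give the first direct comparison of two halogens in one placement, and fluoro in place of chloro on an aromatic carbon, seen in a number 5 percentage points lower from compound 1 to compound 4 (within the scatter), does not separate them, while a number 20 percentage points lower from compound 2 to compound 4 (beyond the scatter) adds a third gap showing that compound 2, with its 4-chlorophenyl, stands clearly apart from every other compound shown. Nothing at hand accounts for these numbers.

The compounds shown leave open what a 4-fluorophenyl would give at this place, and so whether the separate standing of compound 2 goes with the ring placement, with the chlorine, or only with the two together. Also open, going by these compounds, is how a 4-methoxyphenyl, or a longer chain between the phenyl ring and the nitrogen, would read in this assay.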